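The source may report more compounds than this note shows. Statements on the series, on what has been measured and on what is new or still open speak of the compounds shown alone.

Measured so far in a functional assay on cells (Cancer cell lines, Homo sapiens) for cytotoxicity, read by sulforhodamine B assay, with a stated time of 48 h; a higher number here means a weaker inhibitor of growth, a lower number a stronger inhibitor of growth:
compound 1, `O=C1N=C(N2N=C(c3ccccc3)CC2c2ccccc2O)S/C1=C1/C(=O)Nc2ccccc21`, 5370 nM
compound 2, `O=C1N=C(N2N=C(c3ccccc3)CC2c2ccccc2O)S/C1=C1/C(=O)Nc2ccc(Br)cc21`, 720 nM
compound 3, `COc1ccc(C2CC(c3ccc4ccccc4c3)=NN2C2=NC(=O)/C(=C3\C(=O)Nc4ccccc43)S2)cc1`, 12600 nM

Compound 1 and compound 2 share one core and differ in a single place: bromo in place of hydrogen on an aromatic carbon. In this assay this change gave a 7.5-fold lower number from compound 1 to compound 2 (0.87 log units; beyond the scatter). Compound 3 rests on a different core; how the core of compound 3 differs from the core of compound 1 is not broken down here. Of the three measured compounds, compound 3 gives the highest number in this assay, and compound 2 gives the lowest.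

Compound 4, `COc1ccc(C2CC(c3ccc4ccccc4c3)=NN2C2=NC(=O)/C(=C3\C(=O)Nc4ccc(Br)cc43)S2)cc1`, has not yet been measured. It differs from compound 3 by bromo in place of hydrogen on an aromatic carbon, the same change as that from compound 1 to compound 2. For the measured compounds named here, because that earlier change gave a 7.5-fold lower number from compound 1 to compound 2 (0.87 log units; beyond the scatter), a step of comparable direction is expected from compound 3 to compound 4, estimated at a 6.3-fold lower number from compound 3 to compound 4 (0.80 log units; beyond the scatter), although only one earlier instance of the change is available and it sits on a different core. Compound 4 is therefore estimated at 2000 nM in this assay, expected to lie between 700 nM and 6000 nM.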

Compound 4, concentration for total growth inhibition: 210 nM
Estimate against measurement, compound 4: 9.5-fold (0.98 log units) above, and the stated range ends above it.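

In this assay, bromo in place of hydrogen on an aromatic carbon again gave a lower number, with a 60-fold lower number from compound 3 to compound 4 (1.78 log units; beyond the scatter) on the core of compound 3. The direction of the step held on both cores, but its size did not: the same change on two cores in this assay, a 7.5-fold lower number (0.87 log units; beyond the scatter) from compound 1 to compound 2 and a 60-fold lower number (1.78 log units; beyond the scatter) from compound 3 to compound 4, 8.0-fold (0.91 log units) apart, beyond the scatter of two such steps. Thus, in these two pairs, the earlier step pointed the right way but did not fix the size of the later one, and two pairs cannot show what sets that gap or how the change would behave on a further core.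

The compounds shown carry only hydrogen or bromo at this place, which leaves open how a chloro, a fluoro, a methoxy or an amine would compare there. From the compounds shown here alone, it also remains open which part of the difference between the core of compound 1 and the core of compound 3 goes with the larger step.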